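Removing the Methyl from a Shared Nitroimidazole Core

The source may report more compounds than this note shows. Statements on the series, on what has been measured and on what is new or still open speak of the compounds shown alone.

Three close relatives of one shared core have been tested in an ADME assay on MRC5 cells (Homo sapiens) for cytotoxicity, read by resazurin assay, with a stated time of 72 h; a lower number here means a stronger inhibitor, a higher number a weaker inhibitor. Compound 1 `CC1(COc2cccc(-c3ccc(F)nc3)n2)CCn2cc([N+](=O)[O-])nc2O1` carries a 6-fluoropyridin-3-yl group; in this assay compound 1 gives > 64000 nM, which is a limit of the assay rather than a number. Compound 2 `CC1(COc2cccc(-c3ccc(F)cc3F)n2)CCn2cc([N+](=O)[O-])nc2O1` carries a 2,4-difluorophenyl group, and in this assay compound 2 gives > 64000 nM, again a limit. Compound 3 `CC1(COc2cccc(-c3ccc(F)nc3F)n2)CCn2cc([N+](=O)[O-])nc2O1` carries a 2,6-difluoropyridin-3-yl group, and in this assay compound 3 gives > 64000 nM, also a limit. Compound 2 therefore stands exactly where its two relatives stand because all three sit at the limit of > 64000 nM in this assay, at which 3 of the 3 values shown sit. For the same reason the steps a step that the two limits leave unreadable from compound 1 to compound 2, a step that the two limits leave unreadable from compound 1 to compound 3 and a step that the two limits leave unreadable from compound 2 to compound 3 cannot be read in size.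

Compound 4 `O=[N+]([O-])c1cn2c(n1)OC(COc1cccc(-c3ccc(F)cc3F)n1)CC2` differs from compound 2 in one place: hydrogen in place of methyl on a saturated ring carbon. Within the data shown here, none of the measured steps touches this saturated ring carbon; all three concern the aromatic group, and none gives a readable size. With every relative at the limit, the step of a number no higher from compound 2 to compound 4 (the limit leaves the size open) is expected to stay within the scatter. Compound 4 is expected in this assay to give about 64000 nM, within a range from 40000 nM to 120000 nM.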

Compound 4, half-maximal inhibitory concentration: > 64000 nM
Compound 4 ended at the assay's limit (the forecaster's own chance of this, stated with the estimate: 85%); the middle value sits exactly at the limit.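

In this assay compound 4 gives > 64000 nM, which is a limit of the assay and not a number. Compound 2 rests at that same limit, so swapping methyl for hydrogen yields no step of readable size: the limit of > 64000 nM in this assay, at which 4 of the 4 values shown sit.

The compounds shown leave open whether methyl or hydrogen on this saturated ring carbon makes any difference in this assay.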